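Swapping a halogen for dimethylamino on a dienone

The source may hold more compounds than are shown below. What is called first, only, known or untested is meant among the compounds shown, and "the series" means these compounds.

Compound 1 `O=C1C=CCC/C1=C\C=C\c1ccc(Cl)cc1` and compound 2 `O=C1C=CCC/C1=C\C=C\c1ccc(Br)cc1` share one core and differ only in the halogen on the aromatic ring. In a functional assay on HepG2 cells (Homo sapiens) for cytotoxicity, read by MTT assay, with a stated time of 72 h (on this read-out lower numbers stand for stronger inhibition and higher numbers for weaker inhibition), compound 1 gives 3700 nM, and in this assay compound 2 gives 6100 nM. Among the measured compounds shown here, the single measured step, a 1.6-fold higher number from compound 1 to compound 2 (0.22 log units; within the scatter), is too small to separate the two, so compound 2 stands beside its only neighbour with no real gap between them.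

Compound 3 `CN(C)c1ccc(/C=C/C=C2\CCC=CC2=O)cc1` carries the change (dimethylamino in place of bromo on an aromatic carbon). No measured step touches a dimethylamino group; the halogen swap says nothing about a nitrogen-bearing substituent, so there is no shown basis for a direction. The expected step in this assay is therefore a 1.5-fold lower number from compound 2 to compound 3 (0.18 log units; within the scatter), carrying a wide uncertainty. Compound 3 is estimated at 4000 nM, with a range from 1000 nM to 16000 nM.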

Compound 3, half-maximal inhibitory concentration: 1100 nM
For compound 3 the middle estimate is 3.6-fold (0.56 log units) above the measured one; the range from low to high includes it.
By their numbers in this assay, from the lowest: compound 3; then compounds 1 and 2 (each within the scatter of the next).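

The position on the aromatic ring, para to a large group, does respond to what it carries, which the swap between the two halogens could not show. In this assay dimethylamino in place of bromo gives a clear step (a 5.5-fold lower number from compound 2 to compound 3 (0.74 log units; beyond the scatter)), and dimethylamino in place of chloro gives one of similar kind (a 3.4-fold lower number from compound 1 to compound 3 (0.53 log units; beyond the scatter)), so compound 3 is the most active of the three on this read-out. No measured property of these groups is available to account for this gap.

Going by these compounds, it remains open whether a primary amine, a methoxy group or a carboxylic acid at this position would fall near compound 3 or near the two halogen compounds. On these data alone, it is also open whether the same change would give a step of this size on a different core.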